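The source may hold more compounds than are shown below. What is called first, only, known or untested is meant among the compounds shown, and "the series" means these compounds.

For the measured compounds named here, compound 1 `CCCSc1nc(N)c2nc(O)n(Cc3ccccc3)c2n1` is the one compound here with a measured number: in a functional assay (spleen, spleen) for activation, with Mus musculus as the target (a higher number here means that more compound is needed for the effect, a lower number that less compound is needed), compound 1 gives 0.01 uM. Compound 2 `CSc1nc2c(N)ncnc2n1Cc1ccccc1` reaches only the limit of the assay, > 10 uM. Compound 3 `Nc1ncnc2c1nc(I)n2Cc1ccccc1` likewise reaches only the limit, > 10 uM. Going by the values given here, the single step between measured compounds, a step that the two limits leave unreadable from compound 2 to compound 3, cannot be sized, because both of its ends sit at the limit of > 10 uM in this assay, at which 2 of the 3 values shown sit. Compound 4 `CCCNc1nc(N)c2nc(O)n(Cc3ccccc3)c2n1` differs from compound 1 in one place: propylamino in place of propylsulfanyl on an aromatic carbon. Among the compounds with values here, no measured step resembles this exchange of propylsulfanyl for propylamino, and the one step that is known stays unreadable, so the measured data set neither a size nor a direction for it. The expectation therefore rests on compound 1 alone, kept close to its value with room for a modest loss. Compound 4 is expected to need a little more compound than compound 1, a step of a 5.0-fold higher number from compound 1 to compound 4 (0.70 log units; beyond the scatter). The estimate for compound 4 in this assay is 0.05 uM, with a range from 0.01 uM to 0.3 uM.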

Compound 4, minimum effective concentration: 0.1 uM
For compound 4 the middle estimate is 2.0-fold (0.30 log units) below the measured one; the measured number falls inside the stated range.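

This gives the first readable size for a change on the aromatic carbon between two ring nitrogen atoms: in this assay, there is a 10-fold higher number from compound 1 to compound 4 (1.00 log units; beyond the scatter). The propyl chain stays in place, so swapping only the sulfur for a nitrogen that carries a hydrogen-bond donor is enough to move the number beyond the scatter, yet compound 4 still gives a measured 0.1 uM rather than a limit of the assay. Nothing shown says which feature of the exchange accounts for this step.

A single pair cannot show how other links would behave here, such as the oxygen of propoxy or the plain carbon chain of butyl. It also leaves open whether a longer chain on the sulfur, such as pentylsulfanyl, would keep the number of compound 1.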